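Nitro to methoxy on two related cores

The compounds below may be only part of what the source reports. "The series", "measured", "known", "first", "only" and "open" are said of these compounds alone.

Compound 1 `CCN1C(=O)N(CC)C2C1NC(=S)N2/N=C/C=C/c1ccccc1[N+](=O)[O-]` carries a nitro group on its phenyl ring. In a functional assay on A549 cells (Homo sapiens) for inhibition, read by MTT assay, with a stated time of 72 h (a higher number here means a weaker inhibitor, a lower number a stronger inhibitor), compound 1 returns only a limit, > 100000 nM. Compound 2 `CCN1C(=O)N(CC)C2C1NC(=S)N2/N=C/C=C/c1ccccc1OC` differs by methoxy in place of nitro on an aromatic carbon. In this assay compound 2 gives 610 nM. The step of an at least 160-fold lower number from compound 1 to compound 2 (2.21 log units; beyond the scatter) is therefore large, and because the limit of > 100000 nM in this assay, at which 2 of the 3 values shown sit, its true size can only be given as a lower bound.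

Compound 3 `CCN1C(=O)N(CC)C2C1N=C(SC)N2/N=C/C=C/c1ccccc1[N+](=O)[O-]` has a different core; how the core of compound 3 differs from the core of compound 1 is not broken down here. In this assay compound 3 returns only a limit, > 100000 nM. Compound 4 `CCN1C(=O)N(CC)C2C1N=C(SC)N2/N=C/C=C/c1ccccc1OC` has not yet been measured in this assay. For the measured compounds named here, it differs from compound 3 by methoxy in place of nitro on an aromatic carbon, the same change, at the same place, as the one that separates compound 1 from compound 2.

As far as these compounds go, whether the second core carries the same gain is unknown from the two values it has so far; the only fixed point is that compound 3 sits at the limit, as compound 1 does. The step of an at least 66-fold lower number from compound 3 to compound 4 (1.82 log units; beyond the scatter) is expected to be of the same direction as the measured one, resting on the step of an at least 160-fold lower number from compound 1 to compound 2 (2.21 log units; beyond the scatter), with a wider band to allow for the unknown contribution of the core. Compound 4 is thus expected near 1500 nM, estimated between 300 nM and 20000 nM.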

Compound 4, half-maximal inhibitory concentration: 4790 nM
Estimate against measurement, compound 4: 3.2-fold (0.50 log units) below, and the stated range covers the measured number.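

In this assay, 2-nitrophenyl to 2-methoxyphenyl on the second core gives an at least 20-fold lower number from compound 3 to compound 4 (1.31 log units; beyond the scatter), so the change that lowered the number on the core of compound 1 does the same on the core of compound 3. This supports carrying the change across these two cores, in direction only, and the comparison rests on just two pairs of compounds: the same change on two cores in this assay, an at least 160-fold lower number (2.21 log units; beyond the scatter) from compound 1 to compound 2 and an at least 20-fold lower number (1.31 log units; beyond the scatter) from compound 3 to compound 4; the limit leaves it open whether they differ
Neither step has a known true size, and any claim that one core gains more from methoxy than the other remains unsupported, because compound 1 and compound 3 both stand at a limit rather than at a number: the limit of > 100000 nM in this assay, at which 2 of the 4 values shown sit.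

The compounds shown leave open how other groups at this place on the phenyl ring, such as an amine or a carboxylic acid, would read on either core, and whether methoxy elsewhere on the ring would follow the 2-methoxyphenyl compounds. Also open, as far as these compounds go, are the effect of a longer chain on the sulfur of the core of compound 4 and whether either step would hold in any other cell line or read-out.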